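The source may hold more compounds than are shown below. What is called first, only, known or untested is meant among the compounds shown, and "the series" means these compounds.

Measured in a functional assay on NUGC cells (stomach, Homo sapiens) for cytotoxicity; a lower number here means a stronger inhibitor, a higher number a weaker inhibitor:
- compound 1 `N#C/N=C1\N(CCCCCOc2ccc(Cl)cc2)C(=O)CN1c1ccncc1`: 2760 nM
- compound 2 `CC1C(=O)N(CCCCCOc2ccc(Cl)cc2)/C(=N\C#N)N1c1ccncc1`: 1780 nM

Among the measured compounds shown here, compound 2 gives 1780 nM in this assay, and its only neighbour on this scale is compound 1 at 2760 nM. The two differ only by a methyl in place of hydrogen on a saturated ring carbon, and a 1.6-fold lower number from compound 1 to compound 2 (0.19 log units; within the scatter). They therefore cannot be told apart, and compound 2 stands level with compound 1.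

Compound 3 `N#C/N=C1\N(CCCCCOc2ccc(Cl)cc2)C(=O)C(c2ccccc2)N1c1ccncc1` has not been measured yet. Its change from compound 2 is phenyl in place of methyl on a saturated ring carbon.

For the measured compounds named here, only one measured step bears on this, the one made at the same ring carbon, and it involved a far smaller group. It gives no direction to extrapolate, since a 1.6-fold lower number from compound 1 to compound 2 (0.19 log units; within the scatter). Going by the values given here, nothing measured so far shows how a ring at this carbon behaves, so a real move either way remains possible. The expectation in this assay is therefore no step beyond the scatter, though with wide uncertainty: a 1.0-fold higher number from compound 2 to compound 3 (0.00 log units; within the scatter) is the expected step. For compound 3 the estimated value is 1800 nM, with an expected range from 400 nM to 7000 nM.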

Compound 3, half-maximal inhibitory concentration: 3450 nM
For compound 3 the middle estimate is 1.9-fold (0.28 log units) below the measured one; measured number inside the range.
By their numbers in this assay, from the lowest: compounds 2, 1 and 3 (each within the scatter of the next).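

Going from a single carbon to a six-membered aromatic ring on this saturated ring carbon gives no readable step in this assay (a 1.9-fold higher number from compound 2 to compound 3 (0.29 log units; within the scatter)), and the same holds when phenyl is set directly against hydrogen (a 1.3-fold higher number from compound 1 to compound 3 (0.10 log units; within the scatter)). With the earlier comparison of methyl and hydrogen, this means that hydrogen, methyl and phenyl at this position cannot be told apart in this assay, so the position accepts a group far larger than the methyl without a step beyond the scatter. No outside information is available to explain this flat picture.

Still open is whether an amine or a carboxylic acid on this same carbon, or a benzyl group with its extra carbon before the ring, would give a step beyond the scatter, since the groups shown here carry no hydrogen-bond donors or acceptors and no net charge. Also open, on these data alone, is how the numbers respond to changes elsewhere, such as to the pyridin-4-yl group or the five-carbon chain, which all three compounds carry unchanged.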